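A few compounds are considered here, and "the series" means these few. Any claim that something is new, unique, unknown or untested is made for them only; others in the source may bear on it.

Measured in a functional assay on DU-145 cells (Homo sapiens) for antiproliferative activity, read by sulforhodamine B assay, with a stated time of 72 h; on this read-out lower numbers stand for stronger inhibition and higher numbers for weaker inhibition:
- Compound 1 `Fc1ccc(Nc2nncc3ccccc23)cc1` gives 4.3 nM
- Compound 2 `O=S(=O)(Nc1ccccn1)c1ccc(Nc2nncc3ccccc23)cc1` gives 54 nM

Of these two, compound 1 has the lower number and so the stronger inhibition, and the gap to compound 2 lies beyond the usual scatter of this assay. Among the compounds with values here, compound 3 `N#Cc1ccc(Nc2nncc3ccccc23)cc1` has no measurement yet. It keeps the core of compound 1 and makes a single change: cyano in place of fluoro on an aromatic carbon, para to a large group (cyano in place of fluoro on an aromatic carbon).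

Within the data shown here, no measured pair shows this swap, so the data offer no direct guide to its size. Among the measured compounds shown here, the only comparison available is indirect: compound 1 sits at 4.3 nM, while compound 2, which differs from it more widely, sits at 54 nM. Since compound 1 already has the lower number, a modest loss seems more likely than a gain, though a change within the scatter remains possible. The expected move is a 2.8-fold higher number from compound 1 to compound 3 (0.45 log units; beyond the scatter), toward weaker inhibition. For compound 3 the estimated value is 12 nM, with an expected range from 2.5 nM to 60 nM.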

Compound 3, half-maximal inhibitory concentration: 2.1 nM
Compound 3: middle estimate off by 5.7-fold (0.76 log units), on the high side, outside the stated range (below it).
By their numbers in this assay, from the lowest: compound 3; then compound 1; then compound 2.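

Within the data shown here, the step of a 2.0-fold lower number from compound 1 to compound 3 (0.31 log units; beyond the scatter) is the first direct reading of a single change at this aromatic carbon, para to a large group, and in this assay it lies beyond the scatter, though it is modest. It shows that fluoro is not required at this place: cyano, which brings a triple bond outside aromatic rings and a hydrogen-bond acceptor, is accepted here and goes with stronger inhibition rather than a loss. The data offer no measurement that accounts for this step, so the reason for it remains unknown.

Because this is one swap on one core, it cannot show whether the lower number is particular to cyano or would also appear with other groups at this carbon, such as an amine, a carboxylic acid, a methoxy group or a longer chain such as propyl. It also leaves open whether the same swap would move the number in the same direction on a core carrying other changes, or in any read-out other than this assay.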